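Benzyl for Chlorophenyl on the Ring Amine Nitrogen

The compounds below may be only part of what the source reports. "The series", "measured", "known", "first", "only" and "open" are said of these compounds alone.

Compound 1 `Nc1ccccc1NC(=O)c1ccc(CSC(=S)N2CCN(c3ccc(Cl)cc3)CC2)cc1` stands lowest of the two compounds measured in a functional assay on MGC-803 cells (Homo sapiens) for antiproliferative activity, read by CCK-8 assay, with a stated time of 72 h, tested at 2 uM; on this read-out higher numbers stand for a stronger effect at the one concentration tested and lower numbers for a weaker effect. In this assay compound 1 gives 15%. Compound 2 `COC(=O)c1ccc2c(c1)CCN2C(=S)SCc1ccc(C(=O)Nc2ccccc2N)cc1` differs from compound 1 in several places. In this assay compound 2 gives 37.8%, a reading that lies beyond the scatter above that of compound 1; since the two structures differ in several places, the gap cannot be assigned to any single change, and only the two values themselves can be stated.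

Compound 3 `Nc1ccccc1NC(=O)c1ccc(CSC(=S)N2CCN(Cc3ccccc3)CC2)cc1` has not yet been measured in this assay. It differs from compound 1 in one place: benzyl in place of 4-chlorophenyl on an amine nitrogen in a ring. For the measured compounds named here, no measured pair in this set carries the same change, so the size of its step is not known from data; with nothing to anchor it, the expectation is a step that stays within the scatter, in no preferred direction. The estimate therefore means a step of a number 3 percentage points higher from compound 1 to compound 3 (within the scatter), expected to remain within the scatter. Compound 3 is expected to give 18% in this assay, with a range from 5% to 40%.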

Compound 3, a percentage reported as inhibition, at one concentration (the size of the read-out at that concentration, not a potency): 18.1%
Compound 3: middle estimate off by 0.1 percentage points, on the low side; the measured number falls inside the stated range.
By their numbers in this assay, from the lowest: compounds 1 and 3 (each within the scatter of the next); then compound 2.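

Benzyl in place of 4-chlorophenyl on the amine nitrogen in the ring gives, in this assay, a number 3.1 percentage points higher from compound 1 to compound 3 (within the scatter), the first single-place step in the series and the first direct reading at this position. Both groups carry one six-membered aromatic ring of carbon only, and the entering group has no chlorine, so on this one pair neither the chlorine nor the direct attachment of the aromatic ring to the nitrogen is required for a reading at the level of compound 1, though a single step at a single concentration sets no general rule for this position. No measured information on the mechanism or on the properties of these two groups accompanies this step, so the result stands as an observation without an explanation.

Still open, from the compounds shown here alone, is whether a group with no aromatic ring, such as methyl or acetyl, or a longer chain, such as phenylethyl, would move the reading beyond the scatter at this nitrogen. Also open, going by these compounds, is whether benzyl and 4-chlorophenyl would remain indistinguishable at a different concentration or in a full dose-response measurement.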